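Swapping Trifluoromethyl for Bromo on a Tryptophan Dioxygenase Inhibitor

The source may hold more compounds than are shown below. What is called first, only, known or untested is meant among the compounds shown, and "the series" means these compounds.

Three measured compounds share one core and differ only in the aromatic group hung from the linker. Compound 1 `O=[N+]([O-])c1cc(Cl)ccc1CNc1cc(C(F)(F)F)cc2[nH]ncc12` gives 93% in an assay for inhibition of Tryptophan 2,3-dioxygenase (Homo sapiens), with stated times of 10 min and 60 min, tested at 100 uM; on this read-out higher numbers stand for a stronger effect at the one concentration tested and lower numbers for a weaker effect. Compound 3 `O=[N+](O)c1c(Cl)cccc1CNc1cc(C(F)(F)F)cc2[nH]ncc12` gives 94% in this assay. Compound 2 `FC(F)(F)c1cccc(CNc2cc(C(F)(F)F)cc3[nH]ncc23)c1` gives 74% in this assay, the lowest of the three numbers, and both of the others stand above it by more than the usual scatter.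

Compound 4 `FC(F)(F)c1cc(NCc2cccc(Br)c2)c2cn[nH]c2c1` has not yet been measured. It differs from compound 2 in one place: bromo in place of trifluoromethyl on an aromatic carbon. Among the compounds with values here, no pair of measured compounds shows this same swap, so nothing measured fixes its size or direction. Because compound 2 gives 74% and the exchange keeps the ring and its attachment unchanged, the step from compound 2 to compound 4 is expected to stay modest, a number 2 percentage points lower from compound 2 to compound 4 (within the scatter), with either direction possible. Compound 4 is therefore estimated at 72%, most plausibly between 52% and 88%.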

Compound 4, a percentage reported as inhibition, at one concentration (the size of the read-out at that concentration, not a potency): 84%
Beside the measured number, compound 4's estimate is 12 percentage points below it; measured number inside the range.
By their numbers in this assay, from the lowest: compounds 2, 4, 1 and 3 (each within the scatter of the next, the first and the last beyond it).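

Within the data shown here, the first direct reading of bromo in place of trifluoromethyl on this aromatic carbon, meta to a large group, gives a number 10 percentage points higher from compound 2 to compound 4 (within the scatter) in this assay. At this position, then, a single bromine atom can stand where the four heavy atoms of trifluoromethyl stood without the read-out moving beyond the usual scatter, so this one swap gives no sign that the two groups differ here. Nothing available speaks to why the two groups read alike.

Going by these compounds, what an amine, a carboxylic acid or a longer chain would give on this same aromatic carbon stays open. Also open, on these data alone, is whether bromo in place of the other trifluoromethyl, the one on the shared core, would read the same way.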